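The source may report more compounds than this note shows. Statements on the series, on what has been measured and on what is new or still open speak of the compounds shown alone.

Measured compounds and their values:
compound 1 `CCCCCCCCCCCCOC(=O)/C(C#N)=C/c1ccc(O)c(O)c1` gives 45.2%
compound 2 `N#C/C(=C\c1ccoc1)C(=O)Nc1ccccc1` gives 48%
compound 3 `N#C/C(=C\c1cc2ccccc2[nH]1)C(=O)O` gives 25.8%

These three compounds were tested in a functional assay on the whole organism (strain CD1) for inhibition, with Mus musculus as the target, with stated times of 15 min and 20 min, at a dose of 10 mg/kg by the subcutaneous route; a higher number here means more inhibition at the dose given (going by the name of the read-out), a lower number less inhibition. Compound 3 stands lowest of the three; its nearest neighbour in number is compound 1, with a value higher by a margin beyond the usual scatter, and compound 2 lies further above it, also beyond the scatter. Among the measured compounds shown here, no two of the measured compounds differ in only one place, so no step between measured compounds is available.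

Compound 4 `N#C/C(=C\c1cc2ccccc2[nH]1)C(=O)OC1CCCCC1` has not yet been measured. Compared with compound 3 the change is cyclohexyl in place of hydrogen on an oxygen next to a carbonyl group; cut one bond further out, it reads hydroxy to cyclohexyloxy. For the measured compounds named here, nothing among the measured compounds shows what this particular change does. With compound 3 standing lowest and both other compounds higher in this assay, a step upward of moderate size is expected, roughly at the edge of the scatter, as a number 12.2 percentage points higher from compound 3 to compound 4 (beyond the scatter). The estimate for compound 4 in this assay is 38%, with a range from 20% to 58%.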

Compound 4, a percentage reported as inhibition, in the whole organism at one dose (the size of the read-out at that dose, not a potency): 83.6%
The estimate for compound 4 lay 45.6 percentage points below the measured number; measured number above the stated range.
By their numbers in this assay, from the lowest: compound 3; then compounds 1 and 2 (each within the scatter of the next); then compound 4.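

In this assay, among the compounds shown here, the first step that can be read at this position is large: cyclohexyl in place of hydrogen on an oxygen next to a carbonyl group gives a number 57.8 percentage points higher from compound 3 to compound 4 (beyond the scatter) on the shared core. The hydroxy of compound 3 is therefore not required for this read-out, and cyclohexyloxy at the same place, with its six-membered non-aromatic ring of carbon only, is accompanied by a gain rather than a loss. Nothing measured here explains the size of this step.

The compounds shown leave open whether the gain depends on the ring or would appear with any ester, as a methyl ester, an open-chain hexyl ester or an amine-derived amide at this place could show. They also leave open whether a cyclohexyl ester would have the same effect on the cores of compound 1 and compound 2.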